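A few compounds are considered here, and "the series" means these few. Any claim that something is new, unique, unknown or untested is made for them only; others in the source may bear on it.

Three compounds have been measured so far in a functional assay on NCI-H460 cells (Homo sapiens) for antiproliferative activity, read by sulforhodamine B assay, with a stated time of 48 h; on this read-out higher numbers stand for weaker inhibition of growth and lower numbers for stronger inhibition of growth
- compound 1 `CCCCCCCC/C=C\CCCCCCCC(=O)N1CCCC1` with 45.6 ug/mL
- compound 2 `CCCCCC[C@@H](O)C/C=C\CCCCCCCC(=O)N1CCOCC1` with 49.1 ug/mL
- compound 3 `CCCCCCCC/C=C\CCCCCCCC(=O)N1CCCCC1` with 23 ug/mL

Compound 3 stands at the low end of these numbers, within the scatter of compound 1 and beyond it from compound 2. Compound 4 `CCCCCCCC/C=C\CCCCCCCC(=O)N1CCOCC1` differs from compound 3 by morpholin-4-yl in place of piperidin-1-yl on a carbonyl carbon with morpholin-4-yl in place of piperidin-1-yl on a carbonyl carbon. Among the compounds with values here, one measured step bears on this, namely a 2.0-fold lower number from compound 1 to compound 3 (0.30 log units; within the scatter) for another exchange of the group on a carbonyl carbon. Compound 2 also carries morpholin-4-yl but differs elsewhere too, so its 49.1 ug/mL is only a loose guide. In this assay the expected change is small and toward a higher number, with a 1.5-fold higher number from compound 3 to compound 4 (0.18 log units; within the scatter) as the estimated step, not beyond the scatter. Compound 4 is estimated at 35 ug/mL with an expected range from 18 ug/mL to 65 ug/mL in this measurement.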

Compound 4, concentration for 50% growth inhibition: 7.9 ug/mL
Compound 4: the middle estimate sits 4.4-fold (0.65 log units) above what was measured; measured number outside the range, below it.
By their numbers in this assay, from the lowest: compound 4; then compounds 3, 1 and 2 (each within the scatter of the next, the first and the last beyond it).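

In this assay, morpholin-4-yl in place of piperidin-1-yl on a carbonyl carbon brings a 2.9-fold lower number from compound 3 to compound 4 (0.46 log units; beyond the scatter) and in place of pyrrolidin-1-yl brings a 5.8-fold lower number from compound 1 to compound 4 (0.76 log units; beyond the scatter), so this exchange reaches beyond the scatter, which the earlier step between the other two groups did not. With morpholin-4-yl kept, hydrogen in place of hydroxy on a saturated chain carbon bound to two saturated chain carbons gives a 6.2-fold lower number from compound 2 to compound 4 (0.79 log units; beyond the scatter), so the chain matters too. From the compounds shown here alone, whether piperazin-1-yl or a diethylamino group on the carbonyl carbon would match morpholin-4-yl stays open, as does whether the hydroxy exchange reads the same with piperidin-1-yl. Nothing at hand explains these steps.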